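Propyl ketone in place of methyl ester at the carbonyl

This account rests on a few compounds, and the source may have more. Where it says the series, first, only, none or still open, it means among the compounds named here.

Compound 1 `COC(=O)C1=C(C)NC(=O)NC1c1cccs1` gives 19% in an assay on membranes from HEK293 cells for displacement of a labelled ligand from adenosine receptor A2b (Homo sapiens), read by scintillation counting, with a stated time of 30 min, tested at 1 uM; on this read-out lower numbers stand for less inhibition and higher numbers for more inhibition at the one concentration tested (going by the name of the read-out). Among the compounds with values here, its only measured neighbour, compound 2 `COC(=O)C1=C(C)N(C)C(=O)NC1c1cccs1`, gives 17% in this assay; the step of a number 2 percentage points lower from compound 1 to compound 2 (within the scatter) arises from methyl in place of hydrogen on an amide-type nitrogen in a ring and lies within the scatter, so the two compounds stand level and compound 1 has no separation from compound 2 on these numbers.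

Compound 3 `CCCC(=O)C1=C(C)NC(=O)NC1c1cccs1` is not yet measured. It differs from compound 1 at the carbonyl carbon: propyl in place of methoxy on a carbonyl carbon. Within the data shown here, no measured step touches that carbonyl; the single step in hand, a number 2 percentage points lower from compound 1 to compound 2 (within the scatter), concerns the ring nitrogen and carries no information about the carbonyl substituent. In the absence of any bearing step, the step of a number 1 percentage points lower from compound 1 to compound 3 (within the scatter) is expected to stay within the scatter, with wide uncertainty. The estimate for compound 3 is 18%, ranging from 2% to 40%.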

Compound 3, a percentage reported as inhibition, at one concentration (the size of the read-out at that concentration, not a potency): 9%
The estimate for compound 3 lay 9 percentage points above the measured number, and the stated range covers the measured number.
By their numbers in this assay, from the lowest: compounds 3, 2 and 1 (each within the scatter of the next).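

In this assay, the carbonyl carbon now has its first measured step, since the earlier pair differed only at the ring nitrogen: propyl in place of methoxy gives a number 10 percentage points lower from compound 1 to compound 3 (within the scatter) and so leaves the two compounds without separation. On this reading, neither the methoxy oxygen nor the ester form of the carbonyl is shown to matter at this concentration, although a single step at one concentration cannot settle either point. Nothing in hand accounts for the size of this step.

Still open, going by these compounds, is whether a longer chain such as hexyl, an amine-bearing chain or a carboxylic acid at the carbonyl carbon would move the number beyond the scatter from compound 1. Also open, on these data alone, is how propyl at the carbonyl and methyl on the ring nitrogen behave together.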